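This account rests on a few compounds, and the source may have more. Where it says the series, first, only, none or still open, it means among the compounds named here.

Compound 1, `Cc1ccc(S(=O)(=O)Nc2ccc3c(c2)C(=O)N(C)C3=O)cc1`, was tested in an assay on isolated protein for inhibition of lactase/phlorizin hydrolase (Rattus norvegicus), read by colorimetric assay; on this read-out higher numbers stand for weaker inhibition and lower numbers for stronger inhibition. In this assay compound 1 returned only the limit > 200000 nM, so no number is attached to it. Compound 2, `O=C1c2ccc([N+](=O)[O-])cc2C(=O)N1CCNc1ccccc1`, carries a different set of groups on the shared core. In this assay compound 2 also stopped at the limit > 200000 nM. Together these results show where compound 1 stands: at the limit of > 200000 nM in this assay, at which 2 of the 2 values shown sit, so no step between the two measured compounds can be sized. Compound 3, `Cc1ccc(S(=O)(=O)Nc2ccc3c(c2)C(=O)N(CCNc2ccccc2)C3=O)cc1`, has not yet been measured. It differs from compound 1 in one place: anilinomethyl in place of hydrogen on a saturated chain carbon bound to an amide-type nitrogen in a ring. For the measured compounds named here, no measured step sets a scale for this change, and the chain it brings in is also present in compound 2, which likewise gave only a limit. The step from compound 1 to compound 3 is therefore expected to be small, an at least 1.3-fold lower number from compound 1 to compound 3 (0.12 log units; that floor lies within the scatter), with at most a slight move toward stronger inhibition. Compound 3 is estimated to give 150000 nM in this assay, within a range from 30000 nM to 500000 nM, and a limit rather than a number remains a real possibility.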

Compound 3, half-maximal inhibitory concentration: 177000 nM
For compound 3 the middle estimate is 1.2-fold (0.07 log units) below the measured one; the range from low to high includes it.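

For the compounds shown here, compound 3 is the first compound in this set to return an actual number in this assay, which shows that a molecule carrying anilinomethyl on a saturated chain carbon bound to an amide-type nitrogen in a ring can give a value the assay is able to read. Compound 1 remains a limit, > 200000 nM, and not a number. The change can be sized from one side only, as an at least 1.1-fold lower number from compound 1 to compound 3 (0.05 log units; that floor lies within the scatter), so the data give a floor for the step, and a floor of this size does not establish any real gain in inhibition.

From the compounds shown here alone, the true size of the step stays open, since the reading for compound 1 has no number and most of the set still sits at the limit: the limit of > 200000 nM in this assay, at which 2 of the 3 values shown sit. Also open, going by these compounds, is whether the aromatic ring of the new group matters, a question that a plain 2-aminoethyl chain, or a longer chain ending in the same anilino group, would help to answer at this place.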